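Working notes on a small sulfonamide series and one prediction

The source may report more compounds than this note shows. Statements on the series, on what has been measured and on what is new or still open speak of the compounds shown alone.

Measured in a functional assay on RS4-11 cells (Homo sapiens) for inhibition, read by CCK-8 assay, with a stated time of 48 h; a lower number here means a stronger inhibitor, a higher number a weaker inhibitor:
compound 1 `O=[N+]([O-])c1cccc(NC(=S)NCCNS(=O)(=O)c2ccc(-c3ccccc3OCc3ccccc3)s2)c1` gives 11600 nM
compound 2 `O=C(NCCNS(=O)(=O)c1ccc(-c2ccccc2OCc2ccccc2)s1)Nc1cc(Cl)cc(Cl)c1` gives > 20000 nM
compound 3 `Cc1ccc(-c2ccsc2S(=O)(=O)NCCNC(=O)Nc2cc(Cl)cc(Cl)c2)c(Oc2ccc(O)c(O)c2)c1` gives 5100 nM.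

For compound 2 the reported value is a limit of the assay and not a number (the limit of > 20000 nM in this assay, at which 1 of the 3 values shown sits). Compound 2 and compound 1 differ in one place only: a group of 12 heavy atoms (7 carbon, 2 nitrogen, 2 oxygen, 1 sulfur; one six-membered aromatic ring of carbon only) in place of a group of 11 heavy atoms (7 carbon, 1 nitrogen, 1 oxygen, 2 chlorine; one six-membered aromatic ring of carbon only), on an amine nitrogen. That change gives an at least 1.7-fold lower number from compound 2 to compound 1 (0.23 log units; that floor lies within the scatter).

Among the two numbers in this assay, compound 3 stands lowest, with compound 1 as its nearest neighbour. How the core of compound 3 differs from the core of compound 2 is not broken down here.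

Compound 4 `Cc1ccc(-c2ccsc2S(=O)(=O)NCCNC(=S)Nc2cccc([N+](=O)[O-])c2)c(Oc2ccc(O)c(O)c2)c1` has not yet been measured in this assay. It relates to compound 3 exactly as compound 1 relates to compound 2, the same change at the same place: a group of 12 heavy atoms (7 carbon, 2 nitrogen, 2 oxygen, 1 sulfur; one six-membered aromatic ring of carbon only) in place of a group of 11 heavy atoms (7 carbon, 1 nitrogen, 1 oxygen, 2 chlorine; one six-membered aromatic ring of carbon only), on an amine nitrogen.

For compound 4 the expected step in this assay is a 1.7-fold lower number from compound 3 to compound 4 (0.23 log units; within the scatter), resting on compound 2 and compound 1 and their measured step of an at least 1.7-fold lower number from compound 2 to compound 1 (0.23 log units; that floor lies within the scatter), whose floor lies within the scatter, so the expectation is kept modest and the spread wide. For compound 4 the estimate is 3000 nM, expected to fall between 1200 nM and 9000 nM.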

Compound 4, half-maximal inhibitory concentration: 6100 nM
Beside the measured number, compound 4's estimate is 2.0-fold (0.31 log units) below it, within the range that was stated.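

On the core of compound 3, the entering group in place of the (3,5-dichlorophenyl)carbamoyl group on the amine nitrogen gives a 1.2-fold higher number from compound 3 to compound 4 (0.08 log units; within the scatter), so the two compounds cannot be told apart in this assay. Set beside the same change on the other core, this step allows only a limited comparison: the same change on two cores in this assay, an at least 1.7-fold lower number (0.23 log units; that floor lies within the scatter) from compound 2 to compound 1 and a 1.2-fold higher number (0.08 log units; within the scatter) from compound 3 to compound 4; the limit leaves it open whether they differ. The two pairs therefore neither show that the change carries from one core to the other nor show that its outcome depends on the core, and compound 2 stands at a limit of the assay and not at a number: the limit of > 20000 nM in this assay, at which 1 of the 4 values shown sits.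

The change alters two features at once, so the share of the carbonyl-to-thiocarbonyl swap and the share of the ring substituents remain unresolved; a thiocarbonyl version of the (3,5-dichlorophenyl)carbamoyl group, or a carbonyl version of the entering group, would separate them on either core. Also open, as far as these compounds go, is whether any replacement on this nitrogen moves the number beyond the scatter on the core of compound 3, for example a ring bearing an amine or a carboxylic acid, or a longer chain in place of the present one.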